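Acyl variation on the 4-chlorophenylpiperidine valine amides

The compounds below may be only part of what the source reports. "The series", "measured", "known", "first", "only" and "open" are said of these compounds alone.

Measured so far:
compound 1 `CC(C)C(NC(=O)Oc1ccccc1)C(=O)N1CCC(c2ccc(Cl)cc2)CC1`, 265 nM;
compound 2 `CC(C)[C@@H](NC(=O)CC1CC1)C(=O)N1CCC(c2ccc(Cl)cc2)CC1`, 46 nM;
compound 3 `CC[C@@H](C)[C@@H](NC(=O)c1ccccc1)C(=O)N1CCC(c2ccc(Cl)cc2)CC1`, 45 nM.

In an assay on THP-1 cells for displacement of a labelled ligand from C-C chemokine receptor type 1 (Homo sapiens) (on this read-out lower numbers stand for stronger inhibition and higher numbers for weaker inhibition), compound 2 gives 46 nM, the second highest of the three numbers. Compound 3 gives 45 nM, and the two numbers lie within the scatter of each other. Compound 1 gives 265 nM, a higher number than compound 2 beyond the scatter, so compound 1 is the weaker of that pair.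

Compound 4 `CC(C)[C@@H](NC(=O)CCc1ccc(F)cc1)C(=O)N1CCC(c2ccc(Cl)cc2)CC1` is the next member and is not yet measured in this assay. It differs from compound 2 in one place: 4-fluorobenzyl in place of cyclopropyl on a saturated chain carbon bound to a carbonyl carbon. Cut one bond further out, the same change reads cyclopropylmethyl to 2-(4-fluorophenyl)ethyl. Within the data shown here, no direct step between measured compounds covers this change. Compound 3 shows that an aromatic ring on the acyl side gives a number in the same range as compound 2, so no large move is expected. For compound 4 the expected step is a 1.3-fold lower number from compound 2 to compound 4 (0.12 log units; within the scatter), a small change at most. Compound 4 is estimated at 35 nM, with a range from 12 nM to 110 nM.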

Compound 4, half-maximal inhibitory concentration: 70 nM
For compound 4 the middle estimate is 2.0-fold (0.30 log units) below the measured one, within the range that was stated.
By their numbers in this assay, from the lowest: compounds 3, 2 and 4 (each within the scatter of the next); then compound 1.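

In this assay the acyl change gives a 1.5-fold higher number from compound 2 to compound 4 (0.18 log units; within the scatter). At this saturated chain carbon bound to a carbonyl carbon, the exchange of cyclopropyl for 4-fluorobenzyl therefore does not separate the two compounds, even though a six-membered aromatic ring of 8 heavy atoms replaces a three-membered ring of 3. No measurement shown here bears on why the larger group is accommodated.

The compounds shown leave open what the 2-(4-fluorophenyl)ethyl chain would give with the fluorine replaced by hydrogen, an amine or a carboxylic acid on the aromatic ring. They also leave open whether a longer chain carrying the same 4-fluorophenyl ring would keep the number in this range.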